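A few compounds are considered here, and "the series" means these few. Any claim that something is new, unique, unknown or untested is made for them only; others in the source may bear on it.

Measured in a functional assay on NCI/ADR-RES cells (Homo sapiens) for positive allosteric modulation, read by MTT assay, with a stated time of 48 h, tested at 10 uM; on this read-out higher numbers stand for weaker inhibition and lower numbers for stronger inhibition:

compound 1 `C=C1[C@H](O)[C@@H](OC(=O)C(C)(C)C)[C@@H](O)C(C)(C)/C=C/[C@H](C)[C@H](OC(=O)c2ccccc2)[C@@]2(O)C[C@@](C)(O)[C@H](OC(C)=O)[C@@H]2[C@H]1OCC(C)C` gives 64200 nM
compound 2 `C=C1[C@H](O)[C@@H](OC(=O)c2cccc(C)c2)[C@@H](O)C(C)(C)/C=C/[C@H](C)[C@H](OC(=O)c2ccccc2)[C@@]2(O)C[C@@](C)(O)[C@H](OC(C)=O)[C@@H]2[C@H]1OCC(C)C` gives 7640 nM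
compound 3 `C=C1[C@H](OC(C)=O)[C@@H](OC(=O)C(C)(C)C)[C@@H](OC(C)=O)C(C)(C)/C=C/[C@H](C)[C@H](OC(=O)c2ccccc2)[C@@]2(O)C[C@@](C)(O)[C@H](OC(C)=O)[C@@H]2[C@H]1OCC(C)C` gives 1220 nM

Compound 2 differs from compound 1 by 3-methylphenyl in place of tert-butyl on a carbonyl carbon; this brought an 8.4-fold lower number from compound 1 to compound 2 (0.92 log units; beyond the scatter). Among the compounds with values here, compound 3 stands lowest of the three numbers so far, and its difference from compound 1 is not broken down here, since the two cores differ in more than one place.

Compound 4 `C=C1[C@H](OC(C)=O)[C@@H](OC(=O)c2cccc(C)c2)[C@@H](OC(C)=O)C(C)(C)/C=C/[C@H](C)[C@H](OC(=O)c2ccccc2)[C@@]2(O)C[C@@](C)(O)[C@H](OC(C)=O)[C@@H]2[C@H]1OCC(C)C` is not yet measured. It carries, relative to compound 3, the same change seen between compound 1 and compound 2: 3-methylphenyl in place of tert-butyl on a carbonyl carbon. Within the data shown here, because the step of an 8.4-fold lower number from compound 1 to compound 2 (0.92 log units; beyond the scatter) was well beyond the scatter, a drop of similar direction is expected from compound 3 to compound 4, written as a 4.9-fold lower number from compound 3 to compound 4 (0.69 log units; beyond the scatter); with only one earlier instance, a somewhat smaller step is assumed. Compound 4 is therefore estimated at 250 nM in this assay, within 80 nM to 900 nM.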

Compound 4, half-maximal inhibitory concentration: 980 nM
The estimate for compound 4 lay 3.9-fold (0.59 log units) below the measured number; the whole stated range lies below it.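

In this assay, 3-methylphenyl in place of tert-butyl on a carbonyl carbon gave a 1.2-fold lower number from compound 3 to compound 4 (0.10 log units; within the scatter), so the clear drop on the core of compound 1 did not carry over to the core of compound 3, and the two steps differ: the same change on two cores in this assay, an 8.4-fold lower number (0.92 log units; beyond the scatter) from compound 1 to compound 2 and a 1.2-fold lower number (0.10 log units; within the scatter) from compound 3 to compound 4, 6.8-fold (0.83 log units) apart, beyond the scatter of two such steps

The effect of this change therefore depends on the core, and a step read on one core cannot be transferred as a number to the other. Two pairs do not show which of the differences between the cores is responsible, nor why the steps differ.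

On these data alone, whether a longer chain or a pyridine ring on the same carbonyl carbon would also depend on the core remains open. So does whether any such group lowers the number on the core of compound 3.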